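The source may hold more compounds than are shown below. What is called first, only, known or untested is meant among the compounds shown, and "the series" means these compounds.

Compound 1 `C[C@H](C#Cc1cccc(C(=O)NCCC(c2ccc(F)cc2)c2ccc(C(F)(F)F)cc2)c1)N(O)C(N)=O` stands at one end of two numbers that lie within the scatter of each other in an assay for inhibition of Polyunsaturated fatty acid 5-lipoxygenase (Homo sapiens), read by HPLC, with stated times of 15 min and 10 min (on this read-out higher numbers stand for weaker inhibition and lower numbers for stronger inhibition), where compound 1 gives 220 nM. Compound 2 `C[C@H](C#Cc1cccc(C(=O)NCC[C@@H](c2ccc(F)cc2)c2ccc(C(F)(F)F)cc2)c1)N(O)C(N)=O` gives 160 nM in this assay, and the step of a 1.4-fold lower number from compound 1 to compound 2 (0.14 log units; within the scatter) rests on (the fact that one of compounds 1 and 2 is drawn with a defined configuration and the other without, at the place where they differ). Compound 3 `C[C@H](C#Cc1cccc(C(=O)NCCC(c2ccc(F)cc2)c2ccc(F)cc2)c1)N(O)C(N)=O` differs from compound 1 by fluoro in place of trifluoromethyl on an aromatic carbon. Within the data shown here, no measured step touches that group, so the expectation for compound 3 leans only on compound 1 and its 220 nM. Compound 3 is therefore expected to give about 350 nM, between 120 nM and 1000 nM. The expected step of a 1.6-fold higher number from compound 1 to compound 3 (0.20 log units; within the scatter) is modest and uncertain in direction.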

Compound 3, half-maximal inhibitory concentration in the Polyunsaturated fatty acid 5-lipoxygenase assay: 110 nM
Compound 3: middle estimate off by 3.2-fold (0.50 log units), on the high side; measured number outside the range, below it.
By their numbers in the Polyunsaturated fatty acid 5-lipoxygenase assay, from the lowest: compounds 3, 2 and 1 (each within the scatter of the next).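

Among these compounds, in the Polyunsaturated fatty acid 5-lipoxygenase assay compound 1 gives 220 nM and compound 3 gives 110 nM; the change from 4-(trifluoromethyl)phenyl to 4-fluorophenyl gives a 2.0-fold lower number from compound 1 to compound 3 (0.30 log units; within the scatter), so the first step at this position shows no loss of inhibition beyond the scatter. In a physicochemical assay for solubility, at pH 7.4 (on this read-out higher numbers stand for higher solubility and lower numbers for lower solubility), compound 1 gives 3000 nM and compound 3 gives 3000 nM; the same change gives no change at the digits printed from compound 1 to compound 3 (within the scatter), so neither read-out separates the two groups. Nothing at hand accounts for these readings. The compounds shown leave open whether an amine or a nitrile on this aromatic carbon would move either read-out beyond the scatter. They also leave open how a defined configuration at the stereocentre would read with 4-fluorophenyl in place.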